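The compounds below may be only part of what the source reports. "The series", "measured", "known", "first", "only" and "open" are said of these compounds alone.

Compound 1 `N#CC1=C(N)Oc2c(N)cc3nc4ccccc4nc3c2C12C(=O)N(Cc1cnnn1-c1ccccc1Cl)c1ccccc12`: in an ADME assay on L02 cells (Homo sapiens) for antiproliferative activity, read by MTT assay, with a stated time of 48 h (on this read-out lower numbers stand for stronger inhibition and higher numbers for weaker inhibition), compound 1 gives > 50000 nM, which is a limit of the assay and not a number.
Compound 2 `N#CC1=C(N)Oc2c(N)cc3nc4ccccc4nc3c2C12C(=O)N(Cc1cnnn1-c1cccc(Br)c1)c1ccccc12`: compound 2 gives > 50000 nM, again a limit.
Compound 3 `Cc1ccc(-n2nncc2CN2C(=O)C3(C(C#N)=C(N)Oc4c(N)cc5nc6ccccc6nc5c43)c3ccccc32)cc1C`: compound 3 gives > 50000 nM, also a limit.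

Compound 3 therefore stands at the limit, and the two companions shown stand at the same limit, so nothing in these three values separates it from them. The measured steps a step that the two limits leave unreadable from compound 1 to compound 2, a step that the two limits leave unreadable from compound 1 to compound 3 and a step that the two limits leave unreadable from compound 2 to compound 3 all change only the aryl group on the aromatic nitrogen, and each is left unreadable by the two limits. The change from compound 3 to compound 4 `CCc1cccc(CC)c1-n1nncc1CN1C(=O)C2(C(C#N)=C(N)Oc3c(N)cc4nc5ccccc5nc4c32)c2ccccc21` is of the same kind: 2,6-diethylphenyl in place of 3,4-dimethylphenyl on an aromatic nitrogen.

Since the three varied aryl groups all bear on this position and every one of them sits at the limit, as the limit of > 50000 nM in this assay, at which 3 of the 3 values shown sit, records, the expectation for compound 4 in this assay is no readable step beyond the scatter, that is a step that the limit leaves unreadable from compound 3 to compound 4. Compound 4 is expected to give about 80000 nM, within 30000 nM to 200000 nM, most likely again reported only as a limit.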

Compound 4, half-maximal inhibitory concentration: > 50000 nM
Compound 4: a limit, no number; the forecaster's own chance of this, stated with the estimate: 85%; the middle value is on the limit's open side.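

In this assay compound 4 gives > 50000 nM, which is a limit and not a number. Within the data shown here, its steps from compound 1, compound 2 and compound 3 therefore cannot be read, and no new step emerges. Whether the aryl group on the aromatic nitrogen separates these four compounds in this assay stays open, as all share one limit: the limit of > 50000 nM in this assay, at which 4 of the 4 values shown sit.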